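This account rests on a few compounds, and the source may have more. Where it says the series, first, only, none or still open, it means among the compounds named here.

Measured compounds in the series:

compound 1 `O=C(O)c1ccccc1-c1ccc(CCc2ncc(CC3CCC3)[nH]2)cc1` — 7.1 nM
compound 2 `CCCCc1cnc(CCc2ccc(-c3ccccc3C(=O)O)cc2)[nH]1` — 93 nM
compound 3 `O=C(O)c1ccccc1-c1ccc(CCc2ncc(CC3CCCCC3)[nH]2)cc1` — 7.3 nM

In an in vitro functional assay on cells for agonist activity at Bombesin receptor subtype-3 (Mus musculus), read by luminescence and calcium flux (a higher number here means that more compound is needed for the effect, a lower number that less compound is needed), compound 3 gives 7.3 nM. It stands essentially level with compound 1, since a 1.0-fold higher number from compound 1 to compound 3 (0.01 log units; within the scatter) lies within the scatter, while compound 2 is set apart from both: a 13-fold lower number from compound 2 to compound 3 (1.11 log units; beyond the scatter).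

Compound 4 `COc1ccccc1Cc1cnc(CCc2ccc(-c3ccccc3C(=O)O)cc2)[nH]1` differs from compound 3 by 2-methoxyphenyl in place of cyclohexyl on a saturated chain carbon bound to an aromatic carbon.

All three measured steps change the same position, the saturated chain carbon bound to an aromatic carbon. Replacing a ring with an open chain there was costly: a 13-fold higher number from compound 1 to compound 2 (1.12 log units; beyond the scatter). Changing the size of the ring made no difference beyond the scatter: a 1.0-fold higher number from compound 1 to compound 3 (0.01 log units; within the scatter). Going by the values given here, compound 4 keeps a six-membered ring at this position, but an aromatic one carrying a methoxy group; no aromatic group has been measured at this site, so the bearing of the earlier steps is indirect. A ring is retained, which is the feature that separated compound 1 and compound 3 from compound 2, so the step of a 1.6-fold higher number from compound 3 to compound 4 (0.22 log units; within the scatter) is expected to be small, probably within the scatter, with some risk of a higher number.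

Compound 4 is therefore estimated at 12 nM, within a range of 3 nM to 50 nM.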

Compound 4, half-maximal effective concentration: 163 nM
Beside the measured number, compound 4's estimate is 14-fold (1.13 log units) below it, and the stated range ends below it.
By their numbers in this assay, from the lowest: compounds 1 and 3 (each within the scatter of the next); then compounds 2 and 4 (each within the scatter of the next).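

Working notes on the saturated chain carbon bound to an aromatic carbon: in this assay, a ring at this position is not enough to hold the low numbers, as 2-methoxyphenyl in place of cyclohexyl gives a large rise (a 22-fold higher number from compound 3 to compound 4 (1.35 log units; beyond the scatter)) and 2-methoxyphenyl in place of cyclobutyl gives one of similar size (a 23-fold higher number from compound 1 to compound 4 (1.36 log units; beyond the scatter)). Compound 4 instead sits level with the open-chain compound, with 2-methoxyphenyl in place of propyl giving only a 1.8-fold higher number from compound 2 to compound 4 (0.24 log units; within the scatter). Among the four compounds, the low numbers therefore belong to the two with saturated rings, cyclobutyl and cyclohexyl, while compound 2 and compound 4 share the higher level despite their very different groups. Nothing available here bears on the reason for this rise.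

The change from cyclohexyl to 2-methoxyphenyl alters both the ring type and the methoxy group, so the two contributions cannot be separated from these compounds. An unsubstituted phenyl and a methoxy-bearing cyclohexyl at this position would address that question, and cyclopentyl or cycloheptyl would show how far the tolerance for saturated rings extends.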